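Notes on the shared core with varied aryl groups

The compounds below may be only part of what the source reports. "The series", "measured", "known", "first", "only" and "open" are said of these compounds alone.

Measured so far, in an assay for binding affinity to dual specificity mitogen-activated protein kinase kinase 4 (Homo sapiens), read by KINOMEscan, tested at 100 nM; a higher number here means a weaker effect of the compound at the concentration tested, a lower number a stronger effect:
- compound 1 `CCCS(=O)(=O)Nc1ccc(F)c(C(=O)c2n[nH]c3ncc(-c4ccccc4Cl)cc23)c1F`: compound 1 gives 9.3%
- compound 2 `CCCS(=O)(=O)Nc1ccc(F)c(C(=O)c2n[nH]c3ncc(-c4ccc(OC)cc4)cc23)c1F`: compound 2 gives 4.2%
- compound 3 `CCCS(=O)(=O)Nc1ccc(F)c(C(=O)c2n[nH]c3ncc(-c4cccc(O)c4)cc23)c1F`: compound 3 gives 2.2%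

Compound 1 has the highest of the three numbers in this assay. Its nearest neighbour is compound 2, a number 5.1 percentage points lower from compound 1 to compound 2 (within the scatter), and its furthest is compound 3, a number 7.1 percentage points lower from compound 1 to compound 3 (within the scatter). Between the two others the difference is a number 2 percentage points lower from compound 2 to compound 3 (within the scatter). None of these three steps leaves the scatter, so on the numbers shown the three aryl groups on the shared core cannot be told apart in this assay.

Compound 4 `CCCS(=O)(=O)Nc1ccc(F)c(C(=O)c2n[nH]c3ncc(-c4cccc(N(C)C)c4)cc23)c1F` has not been measured. Against compound 1 the change is 3-(dimethylamino)phenyl in place of 2-chlorophenyl on an aromatic carbon.

For the measured compounds named here, the steps that bear on this change are those from compound 1 to compound 2 and to compound 3, in which a different aryl group on the same aromatic carbon gave a step within the scatter each time. Going by the values given here, the entering 3-(dimethylamino)phenyl group is a further variation of the same kind, and no measured pair shows such a variation moving this assay beyond the scatter. The expected step is therefore a number 3.8 percentage points lower from compound 1 to compound 4 (within the scatter), within the scatter, with no direction claimed. Compound 4 is thus estimated at 5.5% in this assay, expected to lie between 0.5% and 15%.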

Compound 4, a percentage reported as activity, at one concentration (the size of the read-out at that concentration, not a potency): 26%
For compound 4 the middle estimate is 20.5 percentage points below the measured one, outside the stated range (above it).
By their numbers in this assay, from the lowest: compounds 3, 2 and 1 (each within the scatter of the next); then compound 4.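

At this aromatic carbon, the choice of aryl group can move this assay beyond the scatter: 3-(dimethylamino)phenyl gives a number 16.7 percentage points higher from compound 1 to compound 4 (beyond the scatter) against 2-chlorophenyl and a number 21.8 percentage points higher from compound 2 to compound 4 (beyond the scatter) against 4-methoxyphenyl. For the compounds shown here, the sharpest comparison is a number 23.8 percentage points higher from compound 3 to compound 4 (beyond the scatter) for dimethylamino in place of hydroxy, since only that group on the aryl ring differs, so the indistinguishable results for compound 1, compound 2 and compound 3 do not extend to every aryl group at this position. Nothing shown accounts for these steps.

With a single compound carrying dimethylamino, the compounds shown leave open whether a 3-aminophenyl or 3-(methylamino)phenyl group would stay with compound 3 or move with compound 4, and whether a larger amine such as morpholine would go further in the same direction. They also leave open whether 4-(dimethylamino)phenyl would give the same result as compound 4, and how a carboxylic acid on the same aryl ring would read in this assay.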